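One Swap, Measured Once, Expected Again

A few compounds are considered here, and "the series" means these few. Any claim that something is new, unique, unknown or untested is made for them only; others in the source may bear on it.

Four compounds share a core and differ in two places: the group on the five-membered ring and a more distant part of the molecule. Compound 1 `Cc1cccc(Cn2cc(C(N)=O)c3c(N)ncnc32)c1` carries a carbamoyl group there. In a functional assay on KB cells (Homo sapiens) for cytotoxicity (a lower number here means a stronger inhibitor, a higher number a weaker inhibitor), compound 1 reaches only > 100000 nM, which is a limit of the assay rather than a number (the limit of > 100000 nM in this assay, at which 1 of the 3 values shown sits). Compound 2 `Cc1cccc(Cn2cc(C(=N)S)c3c(N)ncnc32)c1` differs from it by a group of 3 heavy atoms (1 carbon, 1 nitrogen, 1 sulfur; no ring) in place of a group of 3 heavy atoms (1 carbon, 1 nitrogen, 1 oxygen; no ring), on an aromatic carbon, and in this assay compound 2 gives 30000 nM; the swap produced an at least 3.3-fold lower number from compound 1 to compound 2 (0.52 log units; beyond the scatter). Compound 3 `COc1ccc(Cn2cc(C(N)=O)c3c(N)ncnc32)cc1` has a different distant part, and the difference between its core and that of compound 1 is not broken down here. In this assay compound 3 gives 47000 nM, within the scatter of compound 2. Compound 4 `COc1ccc(Cn2cc(C(=N)S)c3c(N)ncnc32)cc1` is not yet measured. It differs from compound 3 by a group of 3 heavy atoms (1 carbon, 1 nitrogen, 1 sulfur; no ring) in place of a group of 3 heavy atoms (1 carbon, 1 nitrogen, 1 oxygen; no ring), on an aromatic carbon, the same kind of change as that from compound 1 to compound 2. Compound 4 is expected to show a 3.1-fold lower number from compound 3 to compound 4 (0.50 log units; beyond the scatter), resting on an at least 3.3-fold lower number from compound 1 to compound 2 (0.52 log units; beyond the scatter). Compound 4 is therefore estimated at 15000 nM, plausibly between 5000 nM and 40000 nM.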

Compound 4, half-maximal inhibitory concentration: 28000 nM
Compound 4: the middle estimate sits 1.9-fold (0.27 log units) below what was measured; measured number inside the range.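

On the core of compound 3, replacing the carbamoyl group with the sulfur-containing group gives a 1.7-fold lower number from compound 3 to compound 4 (0.22 log units; within the scatter) in this assay, so on this core the swap cannot be told apart from the ordinary spread of repeated measurements. The clear step seen on the core of compound 1 is thus neither shown to carry over in full nor shown to fail, and two cores are too few to establish a rule for the series: the same change on two cores in this assay, an at least 3.3-fold lower number (0.52 log units; beyond the scatter) from compound 1 to compound 2 and a 1.7-fold lower number (0.22 log units; within the scatter) from compound 3 to compound 4; the limit leaves it open whether they differ. Compound 1 stands at a limit of the assay and not at a number: the limit of > 100000 nM in this assay, at which 1 of the 4 values shown sits.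

The compounds shown leave open how a nitrile or a carboxylic acid would compare with these two groups on the same aromatic carbon. They also leave open whether the swap would give a step beyond the scatter on a core whose distant part carries a chlorine atom or an ethyl group.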